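From isopropyl to butyl on a sulfur

The source may hold more compounds than are shown below. What is called first, only, known or untested is meant among the compounds shown, and "the series" means these compounds.

Compound 1 `CCC(C)Sc1nc(C(CC)c2c(F)cccc2Cl)c(C)c(=O)[nH]1` gives > 3000 nM as a limit
Compound 2 `CCCCSc1nc(C(CC)c2c(F)cccc2Cl)c(C)c(=O)[nH]1` gives > 3000 nM as a limit
Compound 3 `Cc1c(O)nc(SC(C)C)nc1C(C)c1c(F)cccc1F` gives > 3000 nM as a limit

All three readings come from an ADME assay on MT4 cells (Homo sapiens) for activation, read by MTT assay (a lower number here means that less compound is tolerated, a higher number that more compound is tolerated), and are limits of the assay, not numbers. Compound 3 stands at the limit of > 3000 nM in this assay, at which 3 of the 3 values shown sit, and so has no exact place among the others. Compound 4 `CCCCSc1nc(O)c(C)c(C(C)c2c(F)cccc2F)n1` differs from compound 3 by butyl in place of isopropyl on a sulfur and by nothing else.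

The nearest measured step is a step that the two limits leave unreadable from compound 1 to compound 2 and its size cannot be read, so it offers no measure for this change. Compound 2, which carries the same butyl, gives > 3000 nM as a limit and shows no number to go below. The expected change in this assay is a step that the limit leaves unreadable from compound 3 to compound 4 and no step beyond the scatter is expected. Compound 4 is expected to report the same limit, and the estimate for compound 4 is 5000 nM with an expected range from 3000 nM to 30000 nM in the measurement to come.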

Compound 4, half-maximal cytotoxic concentration: > 3000 nM
Compound 4: no number, only a limit; the forecaster's own chance of this, stated with the estimate: 85%; the middle value does not contradict the limit.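

No step can be read between compound 3 and compound 4 in this assay, as both readings are limits and not numbers: the limit of > 3000 nM in this assay, at which 4 of the 4 values shown sit.

The compounds shown leave open where any of their half-maximal cytotoxic concentrations lies, and whether butyl in place of isopropyl on a sulfur changes it.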